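Carbamate series: zeta-carotene desaturase inhibition stays at the limit

This account rests on a few compounds, and the source may have more. Where it says the series, first, only, none or still open, it means among the compounds named here.

Compound 1 `CCC(COc1ccc(Cl)cc1)OC(=O)NCc1ccccc1` — > 100000 nM
Compound 2 `CCC(COc1cc(Cl)ccc1Cl)OC(=O)NCc1ccccc1` — > 100000 nM
Compound 3 `CCC(COc1cccc(C(F)(F)F)c1)OC(=O)NCCCc1ccccc1` — > 100000 nM

In an assay for inhibition of zeta-carotene desaturase, chloroplastic/chromoplastic (Capsicum annuum), using a Dixon plot, with a stated time of 8 h (on this read-out lower numbers stand for stronger inhibition and higher numbers for weaker inhibition), compound 1 gives only a limit, > 100000 nM. Compound 2 likewise gives only a limit in this assay, > 100000 nM. Among the compounds with values here, the one step between measured compounds that differ in a single place, a step that the two limits leave unreadable from compound 1 to compound 2, has a limit at both ends, so its size cannot be read. Compound 3 also reaches only a limit in this assay, > 100000 nM. Within the data shown here, compound 3 therefore stands nowhere on a numerical scale: every value shown sits at the limit of > 100000 nM in this assay, at which 3 of the 3 values shown sit, and no compound can be called stronger or weaker than another.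

Compound 4 `CCC(COc1cccc(C(F)(F)F)c1)OC(=O)NCc1ccc(Cl)cc1` is not yet measured. It differs from compound 3 in one place: 4-chlorophenyl in place of phenethyl on a saturated chain carbon bound to an amide-type nitrogen. Among the measured compounds shown here, no measured step bears on this change, and the single step that exists is unreadable. The shared core has given only limits under every variation tried, and nothing among the values shown points to a reading inside the range of this assay. Compound 4 is therefore expected to sit at the limit again, with an estimate of 100000 nM and a range from 30000 nM to 300000 nM. The step of a number no higher from compound 3 to compound 4 (the limit leaves the size open) is expected to be none beyond the scatter.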

Compound 4, half-maximal inhibitory concentration: > 100000 nM
Compound 4 gave a limit, no number; the forecaster's own chance of this, stated with the estimate: 85%; the middle value lies on the limit itself.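

Compound 3 and compound 4 both stay at a limit in this assay, so no size can be read for the change between them. The series remains at one limit: the limit of > 100000 nM in this assay, at which 4 of the 4 values shown sit. The compounds shown leave open whether any variation on the shared core gives a reading inside the range of this assay.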